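Replacing methylcarbamoyl with methylimidazolyl on the benzoxazole

A few compounds are considered here, and "the series" means these few. Any claim that something is new, unique, unknown or untested is made for them only; others in the source may bear on it.

Compound 1 `CCCCN(c1nc2ccccc2o1)[C@H](C)c1ccc(-c2ccccc2-c2nnn[nH]2)cc1`: 3.2 h
Compound 2 `CCCCN(c1nc2c(C(=O)O)cccc2o1)[C@H](C)c1ccc(-c2ccccc2-c2nnn[nH]2)cc1`: 3.7 h
Compound 3 `CCCCN(c1nc2c(C(=O)NC)cccc2o1)[C@H](C)c1ccc(-c2ccccc2-c2nnn[nH]2)cc1`: 1.3 h

In an ADME assay on the whole organism (Macaca fascicularis) for metabolic stability, read by LC-MS, using cassette dosing, at a dose of 1 mg/kg by the oral route (on this read-out higher numbers stand for a longer-lived compound and lower numbers for a shorter-lived compound), compound 3 gives 1.3 h, the shortest half-life of the three measured compounds. Its gap to both neighbours lies beyond the scatter: a 2.5-fold lower number from compound 1 to compound 3 (0.39 log units; beyond the scatter) and a 2.8-fold lower number from compound 2 to compound 3 (0.45 log units; beyond the scatter). The remaining pair shows a 1.2-fold higher number from compound 1 to compound 2 (0.06 log units; within the scatter), so compound 1 and compound 2 cannot be told apart on this read-out.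

Compound 4 `CCCCN(c1nc2c(-c3nccn3C)cccc2o1)[C@H](C)c1ccc(-c2ccccc2-c2nnn[nH]2)cc1` differs from compound 3 in one place: 1-methyl-1H-imidazol-2-yl in place of methylcarbamoyl on an aromatic carbon. Within the data shown here, no measured step shares this exact change. Among the measured compounds shown here, the steps that bear on it are those that put methylcarbamoyl in and take it out again. Both lowered the half-life by a modest amount, so removing that group points toward recovering some of the time seen for compound 1 and compound 2. On these data alone, what the 1-methyl-1H-imidazol-2-yl group itself adds is unknown from these data, and that widens the range.

Compound 4 is therefore expected to show a modest rise, a 1.9-fold higher number from compound 3 to compound 4 (0.28 log units; within the scatter), toward the level of compound 1. The estimate for compound 4 is 2.5 h, with a range from 1 h to 6 h.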

Compound 4, half-life: 3.9 h
The estimate for compound 4 lay 1.6-fold (0.19 log units) below the measured number; the measured number falls inside the stated range.
By their numbers in this assay, from the lowest: compound 3; then compounds 1, 2 and 4 (each within the scatter of the next).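

In this assay, the short half-life of compound 3 proves not to hold for every larger group on this aromatic carbon: 1-methyl-1H-imidazol-2-yl in place of methylcarbamoyl gives a 3.0-fold higher number from compound 3 to compound 4 (0.48 log units; beyond the scatter). The new group, which brings a five-membered aromatic ring to the same place, leaves the read-out indistinguishable from that of the unsubstituted core, with a 1.2-fold higher number from compound 1 to compound 4 (0.09 log units; within the scatter), and from that of the carboxy compound, with a 1.1-fold higher number from compound 2 to compound 4 (0.02 log units; within the scatter). Among the four substituent states shown at this carbon, methylcarbamoyl alone stands apart, and no measurement on hand says why the half-life follows this pattern.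

On these data alone, whether the short half-life of compound 3 goes with the amide hydrogen remains open, and a dimethylcarbamoyl group on this carbon would bear directly on that question. As far as these compounds go, it is equally open whether the N-methyl of the new group matters, which an unsubstituted 1H-imidazol-2-yl group at the same place would test.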